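A few compounds are considered here, and "the series" means these few. Any claim that something is new, unique, unknown or untested is made for them only; others in the source may bear on it.

Compound 1 `COc1ccc(/C=C/c2cc(OC)c(OC)c(OC)c2-c2ccc(OC)cc2)cc1`: 35000 nM
Compound 2 `COc1ccc(/C=C/c2cc(OC)c(OC)c(OC)c2-c2ccc(F)c(F)c2)cc1`: 7500 nM

Within the data shown here, both numbers come from a functional assay on A549 cells (Homo sapiens) for cytotoxicity, read by MTT assay, with a stated time of 48 h (on this read-out lower numbers stand for stronger inhibition and higher numbers for weaker inhibition), where compound 2 has the lower of the two values so far. Compound 3 `COc1ccc(/C=C/c2cc(OC)c(OC)c(OC)c2-c2ccccc2)cc1` has not yet been measured. It differs from compound 2 in one place: phenyl in place of 3,4-difluorophenyl on an aromatic carbon.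

Among the measured compounds shown here, only one measured step bears on this change: a 4.7-fold lower number from compound 1 to compound 2 (0.67 log units; beyond the scatter). For the measured compounds named here, that modest step also involves the 3,4-difluorophenyl group, but no compound carrying plain phenyl has been measured, so the evidence is thin. Compound 3 might be expected to fall somewhere near or between compound 2 and compound 1, which points to a modest rise in the number. The expected change is a 2.0-fold higher number from compound 2 to compound 3 (0.30 log units; within the scatter). For compound 3, the estimated value is 15000 nM, with an expected range from 5000 nM to 45000 nM.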

Compound 3, half-maximal inhibitory concentration: 36000 nM
Compound 3: the middle estimate sits 2.4-fold (0.38 log units) below what was measured; measured number inside the range.
By their numbers in this assay, from the lowest: compound 2; then compounds 1 and 3 (each within the scatter of the next).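

In this assay, phenyl in place of 3,4-difluorophenyl gives a 4.8-fold higher number from compound 2 to compound 3 (0.68 log units; beyond the scatter), so the lower number of compound 2 depends on the two fluorines and not on the presence of an aromatic ring at this position alone. Hydrogen in place of the methoxy group on that ring gives a 1.0-fold higher number from compound 1 to compound 3 (0.01 log units; within the scatter), which means that this change makes no difference that can be told from the scatter. Nothing measured here explains why the fluorines matter at this position.

Going by these compounds, whether a single fluorine on the phenyl ring would be enough remains open. On these data alone, it is equally open whether chlorine, a nitrile or an amine on that ring would bring the number down as the two fluorines do.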